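This account rests on a few compounds, and the source may have more. Where it says the series, first, only, none or still open, it means among the compounds named here.

Compound 1 `CN(Cc1cc(C(F)(F)F)cc(C(F)(F)F)c1)C(=O)c1c(OCCCC(F)(F)F)c2ccccc2n(C)c1=O`: 240 nM
Compound 2 `CN(Cc1cc(C(F)(F)F)cc(C(F)(F)F)c1)C(=O)c1c(N2CCCC2)c2ccccc2n(C)c1=O`: 1100 nM
Compound 3 `CCOc1cc(CN(C)C(=O)c2c(OCCCC3CCN(C(=O)OC(C)(C)C)CC3)c3ccccc3n(C)c2=O)cc(OCC)c1`: 51 nM

Three compounds sharing one core were tested in an assay for inhibition of phosphatidylcholine:ceramide cholinephosphotransferase 2 (Mus musculus), read by mass spectrometry, with stated times of 60 min and 30 min; a higher number here means a weaker inhibitor, a lower number a stronger inhibitor. In this assay compound 3 gives 51 nM, compound 1 gives 240 nM and compound 2 gives 1100 nM, so compound 2 stands with the highest number of the three, beyond the scatter from both of the others.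

Compound 4 `CN(Cc1cc(C(F)(F)F)cc(C(F)(F)F)c1)C(=O)c1c(OCCCC2CCCCC2)c2ccccc2n(C)c1=O` has not yet been measured. It differs from compound 2 in one place: 3-cyclohexylpropoxy in place of pyrrolidin-1-yl on an aromatic carbon. Among the measured compounds shown here, the only measured step that bears on this change is the one that introduced the pyrrolidin-1-yl group, a 4.6-fold higher number from compound 1 to compound 2 (0.66 log units; beyond the scatter), in which an alkoxy chain on that aromatic carbon gave way to the ring. Compound 4 reverses that change and brings in a longer alkoxy chain, as compound 3 also carries on its core. A step back toward a lower number is therefore expected, a 7.3-fold lower number from compound 2 to compound 4 (0.87 log units; beyond the scatter), because the step of a 4.6-fold higher number from compound 1 to compound 2 (0.66 log units; beyond the scatter) ran the other way. Compound 4 is estimated at 150 nM, within a range from 50 nM to 450 nM.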

Compound 4, half-maximal inhibitory concentration: 190 nM
Compound 4: the middle estimate sits 1.3-fold (0.10 log units) below what was measured; the range from low to high includes it.
By their numbers in this assay, from the lowest: compound 3; then compounds 4 and 1 (each within the scatter of the next); then compound 2.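

Replacing the ring with a chain joined through oxygen lowers the number here as well: in this assay, 3-cyclohexylpropoxy in place of pyrrolidin-1-yl gives a 5.8-fold lower number from compound 2 to compound 4 (0.76 log units; beyond the scatter), so compounds 1 and 4, with two different alkoxy chains on this aromatic carbon, both stand beyond the scatter from compound 2. The far end of the chain can also change widely without a readable effect: cyclohexyl in place of trifluoromethyl gives a 1.3-fold lower number from compound 1 to compound 4 (0.10 log units; within the scatter), a step within the scatter. Nothing given here explains either step.

As far as these compounds go, it remains open whether the oxygen itself counts, or whether a 3-cyclohexylpropylamino chain, joined through nitrogen, would give a similar number. Also open, from the compounds shown here alone, is whether a chain ending in an amine or a carboxylic acid would stay within the scatter of compounds 1 and 4.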